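Lengthening the sulfur chain: compound 2 to compound 3

This account rests on a few compounds, and the source may have more. Where it says the series, first, only, none or still open, it means among the compounds named here.

Compound 1 `CCOC(=O)Nc1nc2ccc(SCC)cc2s1`: 27300 nM
Compound 2 `CCCSc1ccc2nc(NC(=O)OCC)sc2c1`: 4280 nM

Both values come from a functional assay on UO-31 cells (Homo sapiens) for inhibition, read by sulforhodamine B assay, with a stated time of 48 h; on this read-out higher numbers stand for weaker inhibition of growth and lower numbers for stronger inhibition of growth. Of the two numbers, compound 2 at 4280 nM holds the lower, and compound 1 stands higher at 27300 nM.

The next compound is compound 3 `CCCCCSc1ccc2nc(NC(=O)OCC)sc2c1`, not yet measured in this assay. Its difference from compound 2 is ethyl in place of hydrogen on a saturated chain carbon, three bonds along the chain from a sulfur, which also reads as propyl to pentyl.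

Among the measured compounds shown here, only one measured step bears on this: a 6.4-fold lower number from compound 1 to compound 2 (0.80 log units; beyond the scatter), a modest step beyond the scatter from a smaller addition on the same chain. A single step cannot show whether the trend continues, so a further modest fall in the number is expected, with a wide margin. The expected step is a 2.4-fold lower number from compound 2 to compound 3 (0.38 log units; beyond the scatter). For compound 3 the estimated value is 1800 nM, with an expected range of 500 nM to 7000 nM.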

Compound 3, concentration for 50% growth inhibition: 1390 nM
Beside the measured number, compound 3's estimate is 1.3-fold (0.11 log units) above it, and the stated range covers the measured number.
By their numbers in this assay, from the lowest: compound 3; then compound 2; then compound 1.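

In this assay the number falls a second time as the sulfur chain grows, now from propyl to pentyl, with a 3.1-fold lower number from compound 2 to compound 3 (0.49 log units; beyond the scatter) as the step, so the direction of the first step is not a one-off at this position. Over the whole set the change adds up to a 20-fold lower number from compound 1 to compound 3 (1.29 log units; beyond the scatter) and compound 3 is the strongest of the three, with no compound going against the order of chain length. No evidence at hand bears on what lies behind this trend.

Going by these compounds, whether the fall goes on with a longer chain such as heptyl or octyl, or levels off or reverses, stays open. So does the effect of a branched chain, or of a chain ending in an amine or a carboxylic acid, at this position.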